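Nitro for fluoro on the N-aryl ring: compound 4

A few compounds are considered here, and "the series" means these few. Any claim that something is new, unique, unknown or untested is made for them only; others in the source may bear on it.

Compound 3 `COc1ccc(C2=Cc3ccc(F)cc3C(CC(=O)C(C)O)N2c2ccc(F)cc2)cc1` gives 1810 nM in an ADME assay on Jurkat cells (Homo sapiens) for cytotoxicity, read by MTT assay, with a stated time of 72 h (a higher number here means that more compound is tolerated, a lower number that less compound is tolerated), the lowest of the three numbers in hand. Compound 1 `COc1ccc(C2=Cc3ccc([N+](=O)[O-])cc3C(CC(C)=O)N2c2ccc(F)cc2)cc1` gives 16400 nM in this assay, and compound 2 `COc1ccc(C2=Cc3ccc(F)cc3C(CC(=O)CO)N2c2ccc([N+](=O)[O-])cc2)cc1` gives 57100 nM; both sit beyond the scatter from compound 3. Compound 4 `COc1ccc(C2=Cc3ccc(F)cc3C(CC(=O)C(C)O)N2c2ccc([N+](=O)[O-])cc2)cc1` differs from compound 3 by nitro in place of fluoro on an aromatic carbon, which one bond further out reads 4-fluorophenyl to 4-nitrophenyl. Among the measured compounds shown here, no measured pair isolates this change; compound 2 also carries the 4-nitrophenyl group and stands highest of the three. The step from compound 3 to compound 4 is expected to raise the number beyond the scatter, a 3.3-fold higher number from compound 3 to compound 4 (0.52 log units; beyond the scatter). Compound 4 is accordingly estimated at 6000 nM, within 1500 nM to 25000 nM.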

Compound 4, half-maximal cytotoxic concentration: 6100 nM
Estimate against measurement, compound 4: 1.0-fold (0.01 log units) below; the range from low to high includes it.
By their numbers in this assay, from the lowest: compound 3; then compound 4; then compound 1; then compound 2.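

In this assay, the change from 4-fluorophenyl to 4-nitrophenyl now has a measured pair, a 3.4-fold higher number from compound 3 to compound 4 (0.53 log units; beyond the scatter), so this place alone moves the number beyond the scatter. With 4-nitrophenyl held, methyl in place of hydrogen on the saturated chain carbon bound to a carbonyl carbon and an oxygen gives a 9.4-fold lower number from compound 2 to compound 4 (0.97 log units; beyond the scatter), so the chain moves the number too, and further. Nothing in hand gives a reason for either step. From the compounds shown here alone, whether an amine or a carboxylic acid on that aromatic carbon would raise the number further stays open. So does the effect of a longer chain in place of that methyl.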